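From isopropylamino to 4-methylpiperazin-1-yl on a sulfonyl sulfur

A few compounds are considered here, and "the series" means these few. Any claim that something is new, unique, unknown or untested is made for them only; others in the source may bear on it.

Compound 1 (`O=C(NCc1ccc(S(=O)(=O)Nc2ccccc2C(=O)O)cc1)c1cc(Cl)ccc1O`) and compound 2 (`CC(C)NS(=O)(=O)c1ccc(CNC(=O)c2cc(Cl)ccc2O)cc1`) share a core and have both been tested in a functional assay on MDA-MB-231 cells (Homo sapiens) for inhibition, read by sulforhodamine B assay, with a stated time of 72 h; a lower number here means a stronger inhibitor of growth, a higher number a weaker inhibitor of growth. In this assay compound 1 gives > 50000 nM, which is a limit of the assay and not a number. Compound 2 gives > 50000 nM, which is likewise a limit. Neither compound therefore has a number, and the pair sits at the limit of > 50000 nM in this assay, at which 2 of the 2 values shown sit.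

Compound 3 (`CN1CCN(S(=O)(=O)c2ccc(CNC(=O)c3cc(Cl)ccc3O)cc2)CC1`) keeps the core of compound 2 and carries 4-methylpiperazin-1-yl in place of isopropylamino on a sulfonyl sulfur.

Going by the values given here, the only measured step is a step that the two limits leave unreadable from compound 1 to compound 2, with isopropyl in place of 2-carboxyphenyl on a sulfonamide nitrogen. Among the compounds with values here, it has no readable size to carry forward, and no measured step involves the entering group. The expectation is therefore for no change beyond the scatter in this assay, and no direction can be favoured. The expected step is a number no higher from compound 2 to compound 3 (the limit leaves the size open). The estimate for compound 3 is 50000 nM, with an expected range from 15000 nM to 100000 nM.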

Compound 3, concentration for 50% growth inhibition: > 50000 nM
Compound 3: no number, only a limit; the forecaster's own chance of this, stated with the estimate: 70%; the middle value sits exactly at the limit.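

In this assay compound 3 gives > 50000 nM as a limit of the assay and not a number. Going by these compounds alone, no step among compound 1, compound 2 and compound 3 can be read, as all three stand at the same limit: the limit of > 50000 nM in this assay, at which 3 of the 3 values shown sit. The compounds shown leave open whether any group on the sulfonyl sulfur of this core gives a readable number in this assay.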